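Sulfonyl substituent variation on a shared oxabicyclic acid core

A few compounds are considered here, and "the series" means these few. Any claim that something is new, unique, unknown or untested is made for them only; others in the source may bear on it.

The series shares one core, carried in compound 1 `O=C(Nc1ccc(S(=O)(=O)NC2CCCCC2)cc1)C1C(C(=O)O)[C@H]2CC[C@@H]1O2` and compound 2 `O=C(Nc1ccc(S(=O)(=O)N2CCOCC2)cc1)C1C(C(=O)O)[C@H]2CC[C@@H]1O2`. In a functional assay on HeLa cells (Homo sapiens) for cytotoxicity, read by MTT assay, with a stated time of 48 h (on this read-out lower numbers stand for stronger inhibition and higher numbers for weaker inhibition), compound 1 gives 18700 nM and compound 2 gives 17200 nM, the lower of the two numbers, though a 1.1-fold lower number from compound 1 to compound 2 (0.04 log units; within the scatter). Compound 3 `O=C(Nc1ccc(S(=O)(=O)NC2CC2)cc1)C1C(C(=O)O)[C@H]2CC[C@@H]1O2` differs from compound 2 by cyclopropylamino in place of morpholin-4-yl on a sulfonyl sulfur. Among the compounds with values here, the only step that bears on it is the exchange on the same sulfonyl sulfur, which stayed within the scatter, so no shift beyond the scatter is expected in this assay, a 1.0-fold higher number from compound 2 to compound 3 (0.02 log units; within the scatter). Compound 3 is therefore estimated at 18000 nM, between 8000 nM and 40000 nM.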

Compound 3, half-maximal inhibitory concentration: 20900 nM
The estimate for compound 3 lay 1.2-fold (0.06 log units) below the measured number; low and high end bracket the measured number.
By their numbers in this assay, from the lowest: compounds 2, 1 and 3 (each within the scatter of the next).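

In this assay, the smaller ring leaves the number within the scatter in both comparisons: a 1.2-fold higher number from compound 2 to compound 3 (0.08 log units; within the scatter), and a 1.1-fold higher number from compound 1 to compound 3 (0.05 log units; within the scatter). Compound 3 thus adds that a three-membered carbon ring on the sulfonamide nitrogen is not told apart from cyclohexyl there, nor from morpholin-4-yl on the sulfonyl sulfur, although morpholin-4-yl has no hydrogen-bond donor. No measurement at hand explains this. From the compounds shown here alone, whether any group on this sulfur can move the number beyond the scatter stays open, for example an open-chain dimethylamino or an aromatic phenylamino group.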